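Moving a hydroxyl on the sulfonyl aryl ring of a benzoxazole sulfonamide

A few compounds are considered here, and "the series" means these few. Any claim that something is new, unique, unknown or untested is made for them only; others in the source may bear on it.

Measured compounds:
- compound 1, `O=S(=O)(Nc1ccc(-c2nc3ccccc3o2)cc1)c1ccccc1O`: > 100000 nM
- compound 2, `COc1cccc(S(=O)(=O)Nc2ccc3oc(-c4ccccc4)nc3c2)c1`: > 100000 nM

The series was examined in an assay on cells for inhibition of HSP60/HSP10 (Homo sapiens), with a stated time of 60 min; on this read-out higher numbers stand for weaker inhibition and lower numbers for stronger inhibition. Compound 1 gave > 100000 nM, which is a limit of the assay and not a number. Compound 2 likewise gave > 100000 nM, again a limit rather than a measured value. For the measured compounds named here, compound 1 therefore stands where the only evidence places both measured compounds, at the limit of > 100000 nM in this assay, at which 2 of the 2 values shown sit. Going by the values given here, no step between two measured compounds is available.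

Compound 3, `O=S(=O)(Nc1ccc(-c2nc3ccccc3o2)cc1)c1ccc(O)cc1`, has not yet been measured. It differs from compound 1 by 4-hydroxyphenyl in place of 2-hydroxyphenyl on a sulfonyl sulfur. Since neither measured compound gave a number in this assay, there is no measured basis for expecting a change beyond the scatter, and the step from compound 1 to compound 3 is expected to be none beyond the scatter, meaning a number no higher from compound 1 to compound 3 (the limit leaves the size open). Compound 3 is therefore estimated to give 100000 nM, within a range of 30000 nM to 300000 nM, and it is expected most likely to return only a limit as well.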

Compound 3, half-maximal inhibitory concentration: 78000 nM
For compound 3 the middle estimate is 1.3-fold (0.11 log units) above the measured one; the range from low to high includes it.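

Compound 3 is the only one of the three compounds shown that returns a number in this assay, namely 78000 nM. Compound 1 gives > 100000 nM, which is a limit of the assay and not a number. The exchange of 2-hydroxyphenyl for 4-hydroxyphenyl on a sulfonyl sulfur, with the same atoms joined differently, gives an at least 1.2-fold lower number from compound 1 to compound 3 (0.10 log units; that floor lies within the scatter), so this position can bring a value into the measurable range, but the change cannot be sized and may lie within the scatter because one end of the step is only a limit: the limit of > 100000 nM in this assay, at which 2 of the 3 values shown sit.

The compounds shown leave open whether the hydroxyl itself matters at this place, or whether a 4-aminophenyl, a 4-carboxyphenyl or an unsubstituted phenyl on the sulfonyl sulfur would give a lower, higher or similar number in this assay. Also open, on these data alone, is whether changes elsewhere on the core of compound 3 could lower the number further, as a single exchange on this ring says nothing about the rest of the molecule.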